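The compounds below may be only part of what the source reports. "The series", "measured", "known", "first", "only" and "open" are said of these compounds alone.

Measured so far: compound 1 `Cc1ccc(NC(=O)c2c(O)c3cccnc3n(-c3ccccc3)c2=O)cc1`, 2.2%; compound 2 `COc1ccc(NC(=O)c2c(O)c3cccnc3n(-c3ccccc3)c2=O)cc1`, -1.9%; compound 3 `Cc1cccc(NC(=O)c2c(O)c3cccnc3n(-c3ccccc3)c2=O)c1`, 4.5%.

These three numbers come from a functional assay on the whole organism for inhibition, with Rattus norvegicus as the target, read by cytopathic effect and paw edema, at a dose of 100 mg/kg by the oral route; a lower number here means less inhibition, a higher number more inhibition at the dose given (going by the name of the read-out). Compound 4 `COc1cccc(NC(=O)c2c(O)c3cccnc3n(-c3ccccc3)c2=O)c1` has not yet been measured there. It differs from compound 3 by methoxy in place of methyl on an aromatic carbon. The same change, (methoxy in place of methyl on an aromatic carbon), has been made once before among these compounds, where it gave a number 4.1 percentage points lower from compound 1 to compound 2 (within the scatter). The two cores carrying the change differ by 3-methylphenyl in place of 4-methylphenyl on an amide-type nitrogen, and the place of the change differs too: in compound 1 the group sits para to a large group, in compound 3 meta to a large group, so this is the same kind of change rather than the same change. A third measured step is a number 2.3 percentage points higher from compound 1 to compound 3 (within the scatter). Because the earlier step of a number 4.1 percentage points lower from compound 1 to compound 2 (within the scatter) stayed within the scatter, the step from compound 3 to compound 4 is expected to be of similar size, a number 4 percentage points lower from compound 3 to compound 4 (within the scatter). Compound 4 is therefore estimated at 0.5%, between -8% and 9%.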

Compound 4, a percentage reported as inhibition, in the whole organism at one dose (the size of the read-out at that dose, not a potency): 20.7%
Beside the measured number, compound 4's estimate is 20.2 percentage points below it, and the stated range ends below it.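

In this assay, methoxy in place of methyl gives a number 16.2 percentage points higher from compound 3 to compound 4 (beyond the scatter), and the 3-methoxyphenyl group also stands apart from the other two amides, with a number 22.6 percentage points higher from compound 2 to compound 4 (beyond the scatter) and a number 18.5 percentage points higher from compound 1 to compound 4 (beyond the scatter). The change therefore does not carry over unchanged from one core to the other: the same change on two cores in this assay, a number 4.1 percentage points lower (within the scatter) from compound 1 to compound 2 and a number 16.2 percentage points higher (beyond the scatter) from compound 3 to compound 4, 20.3 percentage points apart, beyond the scatter of two such steps. Going by these compounds alone, this shows that the outcome depends on the core and on where the group sits, but it rests on only two steps at one dose and does not explain the difference or show that methoxy would help on other cores.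

The compounds shown leave open whether this gain is specific to methoxy or would also appear with a longer chain such as ethoxy, or with an amine or a carboxylic acid at the same place. They also leave open how the effect would change at other doses.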